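Pyridine Nitrogen on the Benzyl Arm of a Dithiocarbamate Series

The source may report more compounds than this note shows. Statements on the series, on what has been measured and on what is new or still open speak of the compounds shown alone.

Measured compounds:
compound 1, `Nc1ccccc1NC(=O)c1ccc(CSC(=S)N2CCN(c3ccc(Cl)cc3)CC2)cc1` — 29%
compound 2, `Nc1ccccc1NC(=O)c1ccc(CSC(=S)N2CCN(c3ccncc3)CC2)cc1` — 90.7%
compound 3, `Nc1ccccc1NC(=O)c1ccc(CSC(=S)N2CCN(Cc3ccccc3)CC2)cc1` — 29.3%

The three compounds share a core and differ only in the group on an amine nitrogen in a ring, read in a functional assay on A-375 cells (Homo sapiens) for antiproliferative activity, read by CCK-8 assay, with a stated time of 72 h, tested at 8 uM; on this read-out lower numbers stand for a weaker effect and higher numbers for a stronger effect at the one concentration tested. Compound 3 sits second highest of the three numbers, but its value and that of compound 1 lie within the scatter of each other, as the step of a number 0.3 percentage points higher from compound 1 to compound 3 (within the scatter) shows. Compound 2 stands apart: the step of a number 61.7 percentage points higher from compound 1 to compound 2 (beyond the scatter) and the reverse step of a number 61.4 percentage points lower from compound 2 to compound 3 (beyond the scatter) are both large and beyond the scatter.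

Compound 4, `Nc1ccccc1NC(=O)c1ccc(CSC(=S)N2CCN(Cc3cccnc3)CC2)cc1`, is the not yet measured partner of compound 3. The change is pyridin-3-yl in place of phenyl on a saturated chain carbon bound to an amine nitrogen in a ring. Among the measured compounds shown here, no measured step places a ring nitrogen on the saturated chain carbon; the only step that adds a ring nitrogen, a number 61.7 percentage points higher from compound 1 to compound 2 (beyond the scatter), puts it on a ring bound directly to the amine nitrogen, and the step that removes it, a number 61.4 percentage points lower from compound 2 to compound 3 (beyond the scatter), also changes the chain. A gain is therefore plausible but far from assured, and the expected step of a number 15.7 percentage points higher from compound 3 to compound 4 (beyond the scatter) is of moderate size with wide uncertainty. Compound 4 is expected to give about 45%, within a range of 20% to 80%.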

Compound 4, a percentage reported as inhibition, at one concentration (the size of the read-out at that concentration, not a potency): 89.2%
Estimate against measurement, compound 4: 44.2 percentage points below, and the stated range ends below it.
By their numbers in this assay, from the lowest: compounds 1 and 3 (each within the scatter of the next); then compounds 4 and 2 (each within the scatter of the next).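

In this assay, among the compounds shown here, the step of a number 59.9 percentage points higher from compound 3 to compound 4 (beyond the scatter) shows that pyridin-3-yl in place of phenyl on a saturated chain carbon bound to an amine nitrogen in a ring is enough for a large gain, with the chain held constant, which no earlier pair could show without also changing the chain. The step of a number 1.5 percentage points lower from compound 2 to compound 4 (within the scatter) places the two pyridine-bearing compounds level despite their different attachment, and the step of a number 60.2 percentage points higher from compound 1 to compound 4 (beyond the scatter) is as large as the gain seen with a pyridine group bound directly to the amine nitrogen, so among these four compounds the two carrying a ring nitrogen stand apart from the two carrying 4-chlorophenyl and benzyl. Nothing available explains why this exchange has so large an effect.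

The compounds shown leave open whether a (pyridin-2-yl)methyl or (pyridin-4-yl)methyl group, or a longer chain such as 2-(pyridin-3-yl)ethyl, would keep this gain. Because every reading comes from a single concentration, they also leave open how the two pyridine-bearing compounds compare in potency.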